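Swapping the aryl group for isopropyl on the amidine nitrogen

The compounds below may be only part of what the source reports. "The series", "measured", "known", "first", "only" and "open" are said of these compounds alone.

Compound 2 `COc1ccc(N/C(CCNC2=CC(=O)c3ccccc3C2=O)=N\S(=O)(=O)c2ccc(C)cc2)c(OC)c1` and compound 1 `Cc1ccc(S(=O)(=O)/N=C(/CCNC2=CC(=O)c3ccccc3C2=O)Nc2ccc(F)c(F)c2)cc1` share the same core and differ only in the group carried by an amine nitrogen. In a functional assay on DU-145 cells (Homo sapiens) for cytotoxicity, read by MTT assay, with a stated time of 48 h (a higher number here means a weaker inhibitor, a lower number a stronger inhibitor), compound 1 gives 12900 nM, and compound 2 gives 67300 nM. Compound 2 is thus the weaker of the two, since the step of a 5.2-fold higher number from compound 1 to compound 2 (0.72 log units; beyond the scatter) lies beyond the scatter, and it stands at the highest number among the two measured.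

Compound 3 `Cc1ccc(S(=O)(=O)/N=C(/CCNC2=CC(=O)c3ccccc3C2=O)NC(C)C)cc1` comes from compound 2 by the change (isopropyl in place of 2,4-dimethoxyphenyl on an amine nitrogen). Within the data shown here, no measured step swaps an aromatic group for a small alkyl group at this place, so the only guide is that the group on this nitrogen matters, because a 5.2-fold higher number from compound 1 to compound 2 (0.72 log units; beyond the scatter) was a modest but real shift between two aryl groups. Whether the isopropyl group lands nearer compound 1 or compound 2 cannot be read from these two numbers alone. A partial return toward the lower end is taken as the central expectation for compound 3, which means an expected step of a 2.2-fold lower number from compound 2 to compound 3 (0.35 log units; beyond the scatter). In this assay compound 3 is therefore estimated at 30000 nM, with a range from 8000 nM to 120000 nM.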

Compound 3, half-maximal inhibitory concentration: 28500 nM
Estimate against measurement, compound 3: 1.1-fold (0.02 log units) above; measured number inside the range.
By their numbers in this assay, from the lowest: compound 1; then compound 3; then compound 2.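

In this assay the group on this amine nitrogen does not have to be aromatic: putting isopropyl in place of 2,4-dimethoxyphenyl gives a 2.4-fold lower number from compound 2 to compound 3 (0.37 log units; beyond the scatter) and the number does not go to either extreme. Measured against the other aryl compound, the same alkyl group gives a 2.2-fold higher number from compound 1 to compound 3 (0.34 log units; beyond the scatter) and so places compound 3 between the two aryl compounds, with both steps beyond the scatter. Having an aromatic ring at this place therefore does not by itself set the order, since compound 1 lies on the stronger side of the isopropyl compound and compound 2 on the weaker side, and no measurement at hand explains this order.

With only one alkyl group among these compounds, it remains open whether a longer chain such as n-butyl, or a saturated ring such as cyclohexyl, would move the number further in either direction. Going by these compounds, it also remains open how a plain phenyl ring without substituents would compare, which would help separate the part played by the ring from that of the fluorine atoms and the methoxy groups on it.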